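Swapping Thiomorpholine for Pyrrolidine on a Shared Core

The source may hold more compounds than are shown below. What is called first, only, known or untested is meant among the compounds shown, and "the series" means these compounds.

Compound 2 `N/C(=N\NC(=S)N1CCSCC1)c1ccccn1` carries a thiomorpholin-4-yl group on its thiocarbonyl carbon. In a functional assay on HeLa cells (Homo sapiens) for cytotoxicity, read by MTT assay, with a stated time of 72 h, tested at 30 uM (a lower number here means less inhibition of growth, a higher number more inhibition of growth at the concentration tested), compound 2 gives 80.6%, the low end of the three numbers in hand, although its neighbours both lie within the scatter: compound 1 `N/C(=N\NC(=S)N1CCCC1)c1ccc(F)cn1` gives 81.2% and compound 3 `N/C(=N\NC(=S)N1CCSCC1)c1ccc(F)cn1` gives 81.7%. The step from compound 2 to compound 3 amounts to a number 1.1 percentage points higher from compound 2 to compound 3 (within the scatter), a fluoro in place of hydrogen on an aromatic carbon.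

Compound 4 `N/C(=N\NC(=S)N1CCCC1)c1ccccn1` differs from compound 2 in one place: pyrrolidin-1-yl in place of thiomorpholin-4-yl on a thiocarbonyl carbon. Going by the values given here, the measured step that bears directly on this change is the one from compound 1 to compound 3, which runs the same exchange in the opposite direction on the fluoro-bearing core and gives a number 0.5 percentage points higher from compound 1 to compound 3 (within the scatter), a change within the scatter. The fluoro step is not the change made here, and it too stayed within the scatter. Nothing among the three compounds therefore points to a shift beyond the scatter in this assay when pyrrolidin-1-yl replaces thiomorpholin-4-yl.

Compound 4 is accordingly expected to give about 81% in this assay, between 73% and 89%. The expected step from compound 2 to compound 4 is a number 0.4 percentage points higher from compound 2 to compound 4 (within the scatter), because the reverse exchange gave only a number 0.5 percentage points higher from compound 1 to compound 3 (within the scatter).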

Compound 4, percent growth inhibition at one concentration: 84.5%
Estimate against measurement, compound 4: 3.5 percentage points below; the range from low to high includes it.
By their numbers in this assay, from the lowest: compounds 2, 1, 3 and 4 (each within the scatter of the next).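

In this assay, the exchange of thiomorpholin-4-yl for pyrrolidin-1-yl on a thiocarbonyl carbon can now be read on the core without fluoro as well as on the fluoro-bearing core, and it gives a number 3.9 percentage points higher from compound 2 to compound 4 (within the scatter). The two readings of this exchange do not separate, so the shift seen for it does not depend on the core beyond the scatter: the same change on two cores in this assay, a number 0.5 percentage points higher (within the scatter) from compound 1 to compound 3 and a number 3.9 percentage points lower (within the scatter) from compound 4 to compound 2, 4.4 percentage points apart, within the scatter of two such steps. Compound 4 also completes the square of four compounds, which allows the fluoro change to be read with pyrrolidin-1-yl on the thiocarbonyl carbon, where it gives a number 3.3 percentage points higher from compound 1 to compound 4 (within the scatter), and this reading likewise agrees with the one made with thiomorpholin-4-yl: the same change on two cores in this assay, a number 1.1 percentage points higher (within the scatter) from compound 2 to compound 3 and a number 3.3 percentage points lower (within the scatter) from compound 4 to compound 1, 4.4 percentage points apart, within the scatter of two such steps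

All four compounds thus lie within the scatter of one another at the single concentration tested, and the data cannot tell whether any of these changes alters growth inhibition at all. The compounds shown leave open whether a piperidin-1-yl or morpholin-4-yl ring, or an open-chain dimethylamino group, on the thiocarbonyl carbon would move the number beyond the scatter.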